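Indole ylidene series: cyano replacing benzoyl beside sulfonyl

A few compounds are considered here, and "the series" means these few. Any claim that something is new, unique, unknown or untested is made for them only; others in the source may bear on it.

Working notes on the shared core. Compound 1 `COc1ccc2[nH]c(-c3ccccc3)c(C=C(C#N)C#N)c2c1` gives 3200 nM in a functional assay on HCT-15 cells (Homo sapiens) for inhibition, read by sulforhodamine B assay, with a stated time of 48 h; on this read-out lower numbers stand for stronger inhibition of growth and higher numbers for weaker inhibition of growth. Compound 2 `CC(=O)/C(=C\c1c(-c2ccccc2)[nH]c2ccccc12)S(=O)(=O)c1ccccc1` gives 836 nM in this assay. Compound 3 `O=C(/C(=C\c1c(-c2ccccc2)[nH]c2ccccc12)S(=O)(=O)c1ccccc1)c1ccccc1` has only "not determined" (no result reported) in this assay, so compound 3 stands without a number against which the next step can be measured. Compound 4 `N#C/C(=C\c1c(-c2ccccc2)[nH]c2ccccc12)S(=O)(=O)c1ccccc1` differs from compound 3 by cyano in place of benzoyl on a double-bonded chain carbon bound to a double-bonded chain carbon and a sulfonyl sulfur. For the measured compounds named here, with no measured step between compound 3 and compound 4, no size or direction of the step is claimed; compound 2 carries a small acyl group at the same place and gives 836 nM. Compound 4 is expected to give about 1200 nM in this assay, within a range from 400 nM to 4000 nM.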

Compound 4, concentration for 50% growth inhibition: 1100 nM
The estimate for compound 4 lay 1.1-fold (0.04 log units) above the measured number; measured number inside the range.
By their numbers in this assay, from the lowest: compounds 2 and 4 (each within the scatter of the next); then compound 1.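

At the double-bonded chain carbon bound to a double-bonded chain carbon and a sulfonyl sulfur, this assay gives a 1.3-fold higher number from compound 2 to compound 4 (0.12 log units; within the scatter), so cyano and acetyl are not told apart at this place. The step involving compound 3 cannot be read, as compound 3 has no number. No measurement at hand bears on what lies behind this result. Open, from the compounds shown here alone, is how a carboxylic acid, an amine or a longer chain would read at this place. Also open, going by these compounds, is whether the same holds with a different sulfonyl substituent in place of phenyl.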